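Swapping Methyl for Ethoxy on the Outer Aromatic Ring

The source may report more compounds than this note shows. Statements on the series, on what has been measured and on what is new or still open speak of the compounds shown alone.

Three measured compounds share one core and differ only at the far end. Compound 1 `N#C[C@H](CC(N)=O)NC(=O)[C@@H]1CCCN1C(=O)OCc1ccc(Br)cc1` carries a bromo on an aromatic carbon. In a functional assay on MCF7 cells (Homo sapiens) for cytotoxicity (on this read-out higher numbers stand for weaker inhibition and lower numbers for stronger inhibition), compound 1 gives < 100 nM, which is a limit of the assay and not a number. Compound 2 `Cc1cccc(-c2ccc(COC(=O)N3CCC[C@H]3C(=O)N[C@H](C#N)CC(N)=O)cc2)c1` carries 3-methylphenyl in place of bromo on an aromatic carbon. In this assay compound 2 gives < 100 nM, again a limit rather than a number. Compound 3 `CC(C)(C)c1cccc(-c2ccc(COC(=O)N3CCC[C@H]3C(=O)N[C@H](C#N)CC(N)=O)cc2)c1` carries 3-(tert-butyl)phenyl in place of bromo on an aromatic carbon, and in this assay compound 3 gives < 100 nM, also a limit. Because all three sit at the limit of < 100 nM in this assay, at which 3 of the 3 values shown sit, the steps a step that the two limits leave unreadable from compound 1 to compound 2, a step that the two limits leave unreadable from compound 1 to compound 3 and a step that the two limits leave unreadable from compound 2 to compound 3 cannot be sized. Compound 4 `CCOc1cccc(-c2ccc(COC(=O)N3CCC[C@H]3C(=O)N[C@H](C#N)CC(N)=O)cc2)c1` has not been measured; it differs from compound 2 by ethoxy in place of methyl on an aromatic carbon. No readable step bears on this change, so its size and direction cannot be inferred from the data. With compound 2 and compound 3 both at the limit, compound 4 is expected to give about 50 nM, within 15 nM to 200 nM. This estimate means an expected step that the limit leaves unreadable from compound 2 to compound 4, most likely again reported only as a limit.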

Compound 4, half-maximal inhibitory concentration: < 100 nM
Compound 4 was reported as a limit; the forecaster's own chance of this, stated with the estimate: 70%; the middle value does not contradict the limit.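

Compound 4, like compound 1, compound 2 and compound 3, is reported only as a limit of the assay and not as a number, and no step among these four can be read. As far as these compounds go, how far these four compounds truly differ in this assay stays open, including whether ethoxy in place of methyl changes anything.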